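Swapping the aryl group on the triazole nitrogen

A few compounds are considered here, and "the series" means these few. Any claim that something is new, unique, unknown or untested is made for them only; others in the source may bear on it.

Measured compounds:
compound 1, `CC(=O)Nc1ccc(-n2nncc2CN2C(=O)C3(C(C#N)=C(N)Oc4c3c3nc5ccccc5nc3c3ccccc43)c3ccccc32)cc1`, > 50000 nM
compound 2, `N#CC1=C(N)Oc2c(N)cc3nc4ccccc4nc3c2C12C(=O)N(Cc1cnnn1-c1cccc(C(F)(F)F)c1)c1ccccc12`, 5400 nM

Of the compounds shown here, two have been measured in a functional assay on A549 cells (Homo sapiens) for antiproliferative activity, read by MTT assay, with a stated time of 48 h; on this read-out higher numbers stand for weaker inhibition and lower numbers for stronger inhibition. Compound 1 has the structure `CC(=O)Nc1ccc(-n2nncc2CN2C(=O)C3(C(C#N)=C(N)Oc4c3c3nc5ccccc5nc3c3ccccc43)c3ccccc32)cc1` and in this assay it reaches only the limit of the assay, > 50000 nM, which is not a number; this is the case noted in the limit of > 50000 nM in this assay, at which 1 of the 2 values shown sits. Going by the values given here, compound 2, `N#CC1=C(N)Oc2c(N)cc3nc4ccccc4nc3c2C12C(=O)N(Cc1cnnn1-c1cccc(C(F)(F)F)c1)c1ccccc12`, is the one compound for which a number is recorded, 5400 nM in this assay. The two compounds differ in more than one place, so their values say nothing about any single change.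

Compound 3, `Cc1cc(C)cc(-n2nncc2CN2C(=O)C3(C(C#N)=C(N)Oc4c(N)cc5nc6ccccc6nc5c43)c3ccccc32)c1`, has not yet been measured. It differs from compound 2 in one place: 3,5-dimethylphenyl in place of 3-(trifluoromethyl)phenyl on an aromatic nitrogen. Among the compounds with values here, no measured pair isolates a change of this kind, so there is no basis for expecting a shift in either direction beyond the scatter.

Compound 3 is therefore expected to sit close to compound 2, with a step of a 1.1-fold lower number from compound 2 to compound 3 (0.03 log units; within the scatter), and its estimated value in this assay is 5000 nM, within a range from 1500 nM to 20000 nM.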

Compound 3, half-maximal inhibitory concentration: 31200 nM
For compound 3 the middle estimate is 6.2-fold (0.80 log units) below the measured one; the whole stated range lies below it.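

In this assay, going by these compounds alone, the aryl group on the aromatic nitrogen of the five-membered ring clearly matters: replacing 3-(trifluoromethyl)phenyl with 3,5-dimethylphenyl gives a 5.8-fold higher number from compound 2 to compound 3 (0.76 log units; beyond the scatter), the first single change that can be read. The two groups share one six-membered aromatic ring of carbon only, have no hydrogen-bond donors or acceptors and carry no net charge, so the step comes from exchanging the trifluoromethyl group for two methyl groups on that ring, though this single pair does not tell why the number rises. Compound 1 remains at a limit of the assay, not a number, and differs from the other compounds in more than one place, so it adds nothing to this step: the limit of > 50000 nM in this assay, at which 1 of the 3 values shown sits.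

The compounds shown leave open whether the step follows from losing the trifluoromethyl group or from having two methyl groups, which a plain phenyl, a chlorophenyl or a methoxyphenyl at this nitrogen could help to separate. They also leave open whether the same exchange would have a similar effect on the core of compound 1.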